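This account rests on a few compounds, and the source may have more. Where it says the series, first, only, none or still open, it means among the compounds named here.

Of the compounds shown here, three have been measured in a toxicity assay on the whole organism with Rattus norvegicus as the target, at a dose of 100 mg/kg by the oral route; on this read-out higher numbers stand for a stronger effect at the one dose given and lower numbers for a weaker effect. Compound 1 `Clc1ccc(OCC2=NCCO2)cc1` gives 30%. Compound 2 `Cc1ccccc1OCC1=NCCO1` gives 40%, and its difference from compound 1 in the core is not broken down here. Compound 3 `Cc1cc(OCC2=NCCO2)ccc1Cl` gives 50%. The step of a number 20 percentage points higher from compound 1 to compound 3 (beyond the scatter) comes with one change, (methyl in place of hydrogen on an aromatic carbon). Compound 2 and compound 1, and compound 2 and compound 3, lie within the usual scatter of each other, so nothing is said of their order.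

Compound 4 `Cc1ccc(OCC2=NCCO2)c(C)c1` has not yet been measured. It differs from compound 2 by methyl in place of hydrogen on an aromatic carbon. This is the same kind of change as from compound 1 to compound 3, but the surroundings differ: there the methyl sits ortho to a chloro group and meta to a group of 7 heavy atoms, here it sits meta to a methyl group and para to a group of 7 heavy atoms. Because the earlier step was a number 20 percentage points higher from compound 1 to compound 3 (beyond the scatter), a step of similar direction but uncertain size is expected, namely a number 10 percentage points higher from compound 2 to compound 4 (within the scatter). Compound 4 is therefore estimated at 50%, between 35% and 65%.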

Compound 4, a percentage reported as activity, at one dose (the size of the read-out at that dose, not a potency): 25%
Beside the measured number, compound 4's estimate is 25 percentage points above it; measured number outside the range, below it.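

In this assay, methyl in place of hydrogen on an aromatic carbon gives a number 15 percentage points lower from compound 2 to compound 4 (beyond the scatter). So a step seen on one core cannot simply be carried to the other in this series, since the same change moves the read-out in opposite directions: the same change on two cores in this assay, a number 20 percentage points higher (beyond the scatter) from compound 1 to compound 3 and a number 15 percentage points lower (beyond the scatter) from compound 2 to compound 4, 35 percentage points apart, beyond the scatter of two such steps. What this does not show is the reason: in compound 4 the new methyl sits meta to a methyl group and para to a group of 7 heavy atoms, and two pairs cannot separate that place from the rest of the core as the source of the difference.

The compounds shown leave open how the step would behave on a third core, or with the methyl at another place on the same ring. They also leave open what a different group on that aromatic carbon, such as an amine, a carboxylic acid or a longer chain, would do to the read-out at this one dose.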